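Swapping Propanoyl for Vinylcarbonyl on a Shared Trimethoxyphenyl Amide

The compounds below may be only part of what the source reports. "The series", "measured", "known", "first", "only" and "open" are said of these compounds alone.

Measured compounds:
Compound 1 `C/C=C/C(=O)N(Cc1cccc(O)c1)c1cc(OC)c(OC)c(OC)c1` gives 14100 nM.
Compound 2 `CCC(=O)N(Cc1ccc(OC)c(O)c1)c1cc(OC)c(OC)c(OC)c1` gives 50 nM.
Compound 3 `C/C=C/C(=O)N(Cc1ccc(OC)c(Br)c1)c1cc(OC)c(OC)c(OC)c1` gives 6430 nM.

These numbers come from a functional assay on MGC-803 cells (Homo sapiens) for inhibition, read by MTT assay, with a stated time of 48 h; on this read-out higher numbers stand for weaker inhibition and lower numbers for stronger inhibition. Compound 2 holds the lowest number of the three, far apart from compound 3 and compound 1. Among the compounds with values here, the only single-point step so far, a 2.2-fold lower number from compound 1 to compound 3 (0.34 log units; beyond the scatter), concerns the benzyl part, not the acyl group.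

Compound 4 `C=CC(=O)N(Cc1ccc(OC)c(O)c1)c1cc(OC)c(OC)c(OC)c1` differs from compound 2 by vinyl in place of ethyl on a carbonyl carbon. Within the data shown here, no measured step touches this carbonyl substituent, so the change is uncharted here; compound 1 and compound 3 carry a different acyl group and a different benzyl group at once, and cannot separate the two. The expected step is therefore small, with a 1.3-fold lower number from compound 2 to compound 4 (0.10 log units; within the scatter) as the working guess. Compound 4 is estimated at 40 nM, between 10 nM and 200 nM.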

Compound 4, half-maximal inhibitory concentration: 62 nM
Beside the measured number, compound 4's estimate is 1.6-fold (0.19 log units) below it, within the range that was stated.
By their numbers in this assay, from the lowest: compounds 2 and 4 (each within the scatter of the next); then compound 3; then compound 1.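

Within the data shown here, on the carbonyl carbon, vinyl in place of ethyl gives a 1.2-fold higher number from compound 2 to compound 4 (0.09 log units; within the scatter), the first reading of a single change at this position. With the rest of the structure the same, the added double bond outside aromatic rings leaves the two numbers indistinguishable on this read-out. No supporting measurement bears on this result.

The compounds shown leave open what a longer chain or an amine on this carbonyl carbon would give. Steps from compound 1 or compound 3 to compound 2 or compound 4 cannot be read, since they differ in more than one place.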